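A few compounds are considered here, and "the series" means these few. Any claim that something is new, unique, unknown or untested is made for them only; others in the source may bear on it.

Series notes.

Compound 1 `COc1cc(/C=C/C(=O)C2=C(/C=C/c3ccc(O)c(OC)c3)NC(=O)NC2c2ccccc2)ccc1O` is the parent of the set. In a functional assay, with a stated time of 20 min, tested at 20 uM (on this read-out higher numbers stand for a stronger effect at the one concentration tested and lower numbers for a weaker effect), compound 1 gives 31%. Compound 2 `COc1cc(/C=C/C(=O)C2=C(/C=C/c3ccc(O)c(OC)c3)NC(=O)NC2c2ccc(C)cc2)ccc1O` carries one alteration on the parent, (methyl in place of hydrogen on an aromatic carbon). In this assay compound 2 gives 36.3%, and the step of a number 5.3 percentage points higher from compound 1 to compound 2 (within the scatter) is small enough to fall inside the usual scatter, so the two readings are treated as equivalent.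

Compound 3 `COc1cc(/C=C/C(=O)C2=C(/C=C/c3ccc(O)c(OC)c3)NC(=S)NC2c2ccccc2)ccc1O` has a different core from compound 1; the difference between the two cores is not broken down here. In this assay compound 3 gives 36.6%, a reading that, set against compound 1 and compound 2, sits within the scatter of both.

Compound 4 `COc1cc(/C=C/C(=O)C2=C(/C=C/c3ccc(O)c(OC)c3)NC(=S)NC2c2ccc(C)cc2)ccc1O` is built on the core of compound 3 and differs from it by methyl in place of hydrogen on an aromatic carbon. The place of the change is described in the same words for both pairs, so this is taken as the same change already seen from compound 1 to compound 2. Going by the values given here, on that basis the step from compound 3 to compound 4 is expected to be about as small as the earlier one, a number 3.4 percentage points higher from compound 3 to compound 4 (within the scatter), because the only measured instance of this change gave a number 5.3 percentage points higher from compound 1 to compound 2 (within the scatter). Among the compounds with values here, only one such pair is known, so the expectation rests on a single step and on compound 3 giving 36.6%. The estimate for compound 4 in this assay is therefore 40%, with a range expected from 29% to 51%.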

Compound 4, a percentage reported as activity, at one concentration (the size of the read-out at that concentration, not a potency): 30%
Beside the measured number, compound 4's estimate is 10 percentage points above it, within the range that was stated.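

Going by these compounds alone, on the core of compound 3, the change from phenyl to 4-methylphenyl reads in this assay as a number 6.6 percentage points lower from compound 3 to compound 4 (within the scatter), so the methyl group gives no step that can be told from repeat noise on this core. Set beside the earlier step on the core of compound 1, the two results do not differ, and the change carries from one core to the other as a step inside the scatter on both: the same change on two cores in this assay, a number 5.3 percentage points higher (within the scatter) from compound 1 to compound 2 and a number 6.6 percentage points lower (within the scatter) from compound 3 to compound 4, 11.9 percentage points apart, within the scatter of two such steps. This does not show that the methyl group raises or lowers the read-out on either core, and the opposite signs of the two steps are no sign that the core alters the effect of the change, since two pairs that each stay within the scatter cannot separate such an effect from noise.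

On these data alone, it remains open whether a chlorine atom, a methoxy group, an amine or a carboxylic acid in place of the methyl group on that six-membered aromatic ring would give a step beyond the scatter on either core. As far as these compounds go, all these readings also come from a single concentration, so how the compounds compare in potency remains open as well.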